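Swapping the aryl substituent on a chalcone-like cytotoxic scaffold

The source may hold more compounds than are shown below. What is called first, only, known or untested is meant among the compounds shown, and "the series" means these compounds.

Measured so far:
- compound 1, `CC1=C(/C=C/C(=O)/C=C/c2ccc(Cl)cc2)C(C)(C)CCC1`: 33200 nM
- compound 2, `CC1=C(/C=C/C(=O)/C=C/c2ccc([N+](=O)[O-])cc2)C(C)(C)CCC1`: 28700 nM

Both compounds share a core in which a cyclic alkene is joined through a dienone chain to an aromatic ring; they differ only in the group on that ring. In a functional assay on HeLa cells (Homo sapiens) for cytotoxicity, read by sulforhodamine B assay, with a stated time of 48 h (on this read-out higher numbers stand for weaker inhibition and lower numbers for stronger inhibition), compound 1 gives 33200 nM, and compound 2 gives 28700 nM. Going by the values given here, the single step that exists, a 1.2-fold lower number from compound 1 to compound 2 (0.06 log units; within the scatter), is within the scatter, so compound 1 and compound 2 cannot be told apart on these numbers.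

Compound 3, `CC1=C(/C=C/C(=O)/C=C/c2ccccc2F)C(C)(C)CCC1`, is not yet measured. Its change from compound 1 is 2-fluorophenyl in place of 4-chlorophenyl on a double-bonded chain carbon bound to a double-bonded chain carbon. Among the compounds with values here, no measured step involves a fluorine or a substituent in this position of the ring, so the only guidance is that the one exchange on the aromatic ring tried so far left the result unchanged. On that thin basis the expectation is a step of about a 1.1-fold higher number from compound 1 to compound 3 (0.02 log units; within the scatter), that is, no change beyond the scatter. Compound 3 is therefore estimated at 35000 nM, with a range from 14000 nM to 90000 nM.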

Compound 3, half-maximal inhibitory concentration: 41900 nM
Beside the measured number, compound 3's estimate is 1.2-fold (0.08 log units) below it, within the range that was stated.
By their numbers in this assay, from the lowest: compounds 2, 1 and 3 (each within the scatter of the next).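

Putting 2-fluorophenyl in place of 4-chlorophenyl in this assay gives a 1.3-fold higher number from compound 1 to compound 3 (0.10 log units; within the scatter), so these two compounds cannot be told apart on these numbers. This exchange reaches further than the step to compound 2. The two group names show that both the halogen and its place on the ring differ, yet the result still does not rise above the ordinary spread of repeated measurements. No separate measurement on these groups accompanies this result, so the numbers offer no explanation for it.

Each aromatic ring shown carries only a single chlorine, fluorine or nitro group, so it remains open whether an amine, a carboxylic acid or a longer chain on the ring would give a number clearly separated from these. As far as these compounds go, because two features differ at once between compound 1 and compound 3, the separate contributions of the halogen and its place also remain open, and 4-fluorophenyl and 2-chlorophenyl are the groups that could separate them.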